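A few compounds are considered here, and "the series" means these few. Any claim that something is new, unique, unknown or untested is made for them only; others in the source may bear on it.

Compounds measured for lipophilicity:
compound 1, `CS/C(=N\C#N)NCc1ccc(Cl)nc1`, 1.27;
compound 2, `CS/C(=N\C#N)N(C)Cc1ccc(Cl)nc1`, 1.4;
compound 3, `CN/C(=N\C#N)NCc1ccc(Cl)nc1`, 0.84.

In a physicochemical assay for lipophilicity, using the shake flask method, measured as octanol-water partition, at 23 degrees C (a higher number here means a more lipophilic compound, a lower number a more polar compound), compound 1 stands second highest of the three; compound 2 lies a number 0.13 log units higher from compound 1 to compound 2 (within the scatter), within the scatter, while compound 3 lies a number 0.43 log units lower from compound 1 to compound 3 (beyond the scatter). Compound 4, `CCN/C(=N\C#N)NCc1ccc(Cl)nc1`, differs from compound 1 by ethylamino in place of methylsulfanyl on a carbon with a double bond to nitrogen. The step to compound 3 bears on this directly, as it swaps the same methylsulfanyl for an amino group, and it gave a modest drop; the step to compound 2 shows that one added methyl on an amine nitrogen moved this assay only within the scatter. The extra carbon of ethylamino is therefore expected to offset part, but not all, of that drop, so a small decrease is expected in this assay: a number 0.07 log units lower from compound 1 to compound 4 (within the scatter). Compound 4 is thus estimated at 1.2, ranging from 0.8 to 1.6.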

Compound 4, partition coefficient: 0.86
For compound 4 the middle estimate is 0.34 log units above the measured one; the range from low to high includes it.
By their numbers in this assay, from the lowest: compounds 3 and 4 (each within the scatter of the next); then compounds 1 and 2 (each within the scatter of the next).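

In this assay ethylamino in place of methylsulfanyl on a carbon with a double bond to nitrogen gives a number 0.41 log units lower from compound 1 to compound 4 (beyond the scatter) and so repeats the modest drop seen with methylamino at this position. The extra methyl on the saturated chain carbon bound to an amine nitrogen comes with a number 0.02 log units higher from compound 3 to compound 4 (within the scatter) and does not offset that drop. No measurement shown accounts for this result. Open, as far as these compounds go, is whether a longer chain such as propylamino, or a cyclic amine such as pyrrolidine, at this carbon would stay level with compound 3 and compound 4.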